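This account rests on a few compounds, and the source may have more. Where it says the series, first, only, none or still open, it means among the compounds named here.

Compound 3 `CSc1nc(N)nc2c1ncn2/C=C1/CC1(CO)CO` belongs to a small group of compounds built on one shared core. In an ADME assay on CCRF-HSB-2 cells (Homo sapiens) for cytotoxicity, with a stated time of 7 days (a higher number here means that more compound is tolerated, a lower number that less compound is tolerated), compound 3 gives > 100000 nM, which is a limit of the assay rather than a number (the limit of > 100000 nM in this assay, at which 1 of the 3 values shown sits). Compound 1 `CC(C)CSc1nc(N)nc2c1ncn2/C=C1/CC1(CO)CO` carries a larger group on the same saturated chain carbon bound to a sulfur, and in this assay compound 1 gives 60000 nM. Compound 2 `CCCCCCCCOc1nc(N)nc2c1ncn2/C=C1/CC1(CO)CO` differs from compound 1 on an aromatic carbon, and in this assay compound 2 gives > 20000 nM, also a limit (the limit of > 20000 nM in this assay, at which 1 of the 3 values shown sits). The not yet measured compound 4 `Nc1nc(SCc2ccccc2)c2ncn(/C=C3/CC3(CO)CO)c2n1` differs from compound 3 by phenyl in place of hydrogen on a saturated chain carbon bound to a sulfur. The measured step that bears on this change is an at least 1.6-fold higher number from compound 1 to compound 3 (0.22 log units; that floor lies within the scatter), a move from a larger group to hydrogen at that same carbon whose size lies within the usual scatter. With phenyl entering there, the change reading methylsulfanyl to benzylsulfanyl, the expected step is an at least 2.5-fold lower number from compound 3 to compound 4 (0.39 log units; beyond the scatter), toward a lower number but modest. Compound 4 is therefore estimated at 40000 nM, with a range from 10000 nM to 100000 nM.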

Compound 4, half-maximal cytotoxic concentration: > 100000 nM
Compound 4 was reported as a limit; the forecaster's own chance of this, stated with the estimate: 30%; at least 2.5-fold (0.39 log units) between middle value and limit.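

In this assay compound 4 gives > 100000 nM, a limit rather than a number, so adding phenyl at this saturated chain carbon bound to a sulfur produced no value that can be read as a number: the limit of > 100000 nM in this assay, at which 2 of the 4 values shown sit. Phenyl in place of isopropyl at that carbon gives an at least 1.6-fold higher number from compound 1 to compound 4 (0.22 log units; that floor lies within the scatter), a floor too small to set the two apart. The steps to compound 4 from the other two compounds cannot be read, as both ends of each are limits.

From the compounds shown here alone, how far the true values lie past these limits stays open. Also open, going by these compounds, is what an amine or a longer chain at this carbon would do to the concentration tolerated.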